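The source may report more compounds than this note shows. Statements on the series, on what has been measured and on what is new or still open speak of the compounds shown alone.

Compound 1 `C=CCC/C=C\C=C/CCCCCCCC[C@H]1CC[C@H]([C@@H]2CC[C@@H](CC(=O)O)OO2)O1`, compound 2 `C=CCCC/C=C/C=C\CCCCCCCC[C@H]1CC[C@H]([C@@H]2CC[C@@H](CC(=O)O)OO2)O1` and compound 3 `C=CCCC/C=C/C=C\CCCCCCCC[C@H]1CC[C@H]([C@@H]2CC[C@@H](CC(=O)OC)OO2)O1` share one core and were each tested in a functional assay on MEL28 cells (Homo sapiens) for cytotoxicity; a higher number here means a weaker inhibitor, a lower number a stronger inhibitor. In this assay compound 2 gives 0.1 ug/mL, compound 3 gives 0.1 ug/mL, and compound 1 gives 0.5 ug/mL. Two changes connect them. The first, (a group of 6 heavy atoms (6 carbon; no ring) in place of a group of 7 heavy atoms (7 carbon; no ring), on a double-bonded chain carbon bound to a double-bonded chain carbon), produced a 5.0-fold higher number from compound 2 to compound 1 (0.70 log units; beyond the scatter). The second, (methyl in place of hydrogen on an oxygen next to a carbonyl group), gave no change at the digits printed from compound 2 to compound 3 (within the scatter).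

Compound 4 `C=CCC/C=C\C=C/CCCCCCCC[C@H]1CC[C@H]([C@@H]2CC[C@@H](CC(=O)OC)OO2)O1` is not yet measured. It differs from compound 3 by a group of 6 heavy atoms (6 carbon; no ring) in place of a group of 7 heavy atoms (7 carbon; no ring), on a double-bonded chain carbon bound to a double-bonded chain carbon, the same change that led from compound 2 to compound 1, made on a core that differs from that of compound 2 by methyl in place of hydrogen on an oxygen next to a carbonyl group. Because a 5.0-fold higher number from compound 2 to compound 1 (0.70 log units; beyond the scatter) was seen once, a step of similar size is expected from compound 3 to compound 4, namely a 5.0-fold higher number from compound 3 to compound 4 (0.70 log units; beyond the scatter). Compound 4 is therefore estimated at 0.5 ug/mL, plausibly between 0.2 ug/mL and 1.2 ug/mL.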

Compound 4, half-maximal inhibitory concentration: 0.5 ug/mL
Estimate against measurement, compound 4: no gap at the digits printed, within the range that was stated.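

In this assay, among these compounds, replacing hepta-1,6-dien-1-yl with the chain of 6 carbon atoms gives a 5.0-fold higher number from compound 3 to compound 4 (0.70 log units; beyond the scatter), and this step matches the one seen on the other core: the same change on two cores in this assay, a 5.0-fold higher number (0.70 log units; beyond the scatter) from compound 2 to compound 1 and a 5.0-fold higher number (0.70 log units; beyond the scatter) from compound 3 to compound 4, 1.0-fold (0.00 log units) apart, within the scatter of two such steps Placing methyl on the oxygen next to the carbonyl group gives no change at the digits printed from compound 1 to compound 4 (within the scatter), which also agrees with the earlier step: the same change on two cores in this assay, no change at the digits printed (within the scatter) from compound 2 to compound 3 and no change at the digits printed (within the scatter) from compound 1 to compound 4, 1.0-fold (0.00 log units) apart, within the scatter of two such steps Each change therefore carried over between the two cores here, but with only two cores per change, this does not show that either would carry over to other cores.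

The compounds shown leave open how a longer chain would behave. They also leave open what an amide would do in place of the carboxylic acid or its methyl ester.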